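This account rests on a few compounds, and the source may have more. Where it says the series, first, only, none or still open, it means among the compounds named here.

Compound 3, `CN(C)C(=O)c1cc2cnc(Nc3ccc(NC(=O)CCCCN=C=S)cc3)nc2n1C1CCCC1`, gives 82.5% in a functional assay on NCI-H1299 cells (Homo sapiens) for inhibition, read by CCK-8 assay, with a stated time of 72 h, tested at 10 uM (on this read-out higher numbers stand for a stronger effect at the one concentration tested and lower numbers for a weaker effect), which places it second of the three measured compounds, within the scatter of both neighbours. Compound 1, `CN(C)C(=O)c1cc2cnc(Nc3ccc(C(=O)NCCCCCCN=C=S)cc3)nc2n1C1CCCC1`, gives 85% in this assay, and compound 2, `CN(C)C(=O)c1cc2cnc(Nc3ccc(NC(=O)CCCN=C=S)cc3)nc2n1C1CCCC1`, gives 78.8%. The three differ only in the chain that carries the isothiocyanate: the step of a number 6.2 percentage points lower from compound 1 to compound 2 (within the scatter) and the step of a number 2.5 percentage points lower from compound 1 to compound 3 (within the scatter) are both within the scatter, as is the step of a number 3.7 percentage points higher from compound 2 to compound 3 (within the scatter). None of these changes in chain length moved the read-out beyond the scatter.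

Compound 4, `CN(C)C(=O)c1cc2cnc(Nc3ccc(N=C=S)cc3)nc2n1C1CCCC1`, takes this further: a group of 3 heavy atoms (1 carbon, 1 nitrogen, 1 sulfur; no ring) in place of a group of 10 heavy atoms (6 carbon, 2 nitrogen, 1 oxygen, 1 sulfur; no ring), on an aromatic carbon. Among the measured compounds shown here, no measured step removes the amide and the whole chain in this way, so the three steps give only indirect guidance, each of them being small. Compound 4 is therefore expected to sit near compound 3, with a step of a number 8.5 percentage points lower from compound 3 to compound 4 (within the scatter) expected in this assay. For compound 4 the estimate in this assay is 74%, expected to fall between 52% and 92%.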

Compound 4, a percentage reported as inhibition, at one concentration (the size of the read-out at that concentration, not a potency): 83.7%
For compound 4 the middle estimate is 9.7 percentage points below the measured one, and the stated range covers the measured number.
By their numbers in this assay, from the lowest: compounds 2, 3, 4 and 1 (each within the scatter of the next).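

Taking out the amide and the whole chain, so that the isothiocyanate sits directly on the aromatic carbon, para to a large group, gives a number 1.2 percentage points higher from compound 3 to compound 4 (within the scatter) and a number 4.9 percentage points higher from compound 2 to compound 4 (within the scatter) and also a number 1.3 percentage points lower from compound 1 to compound 4 (within the scatter) in this assay. The earlier compounds shown here varied only the chain that carries the isothiocyanate, while these steps show that, at this one concentration, the read-out stays within the scatter even when the amide and the chain are both gone. No measurement given here accounts for this result.

The compounds shown leave open whether the isothiocyanate itself matters, since each of them carries it, and an amine or an acrylamide at this carbon would address that. They also leave open whether these four compounds would separate across a full range of concentrations.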